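Working notes on a small efficacy series

This account rests on a few compounds, and the source may have more. Where it says the series, first, only, none or still open, it means among the compounds named here.

Measured compounds and their responses:
compound 1 `O=C(O)CCc1ccc(OCc2cccc(C(F)(F)F)c2)cc1`: 103%
compound 2 `O=C(O)CCc1ccc(OCc2cccc(-c3ccccc3)c2)cc1`: 105%
compound 3 `Cc1ccc(-c2cccc(COc3ccc(CCC(=O)O)cc3)c2)cc1`: 86%

In a functional assay on 1321-N1 cells for agonist activity at Free fatty acid receptor 1 (Homo sapiens), read by calcium flux (a higher number here means a larger maximal response, a lower number a smaller maximal response), compound 1 gives 103%, compound 2 gives 105% and compound 3 gives 86%. Compound 3 stands lowest of the three numbers: a number 17 percentage points lower from compound 1 to compound 3 (beyond the scatter) and a number 19 percentage points lower from compound 2 to compound 3 (beyond the scatter), whereas a number 2 percentage points higher from compound 1 to compound 2 (within the scatter), so compound 1 and compound 2 cannot be ordered against each other.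

Compound 4 `COc1ccccc1-c1cccc(COc2ccc(CCC(=O)O)cc2)c1` is not yet measured. Its change from compound 3 is 2-methoxyphenyl in place of 4-methylphenyl on an aromatic carbon. Going by the values given here, of the measured steps, the one most directly related is the methyl in place of hydrogen step, a number 19 percentage points lower from compound 2 to compound 3 (beyond the scatter), since in compound 4 that methyl is gone again; the methoxy that enters has no measured counterpart. A step upward from compound 3 is therefore expected, of a size comparable to a reversal of that earlier loss: a number 11 percentage points higher from compound 3 to compound 4 (beyond the scatter) is the expected step. For compound 4 the estimate is 97%, with an expected range from 82% to 110%.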

Compound 4, largest response reached (reported as efficacy), in percent of the reference or control that the assay uses: 105%
The estimate for compound 4 lay 8 percentage points below the measured number; measured number inside the range.
By their numbers in this assay, from the lowest: compound 3; then compounds 1, 2 and 4 (each within the scatter of the next).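

In this assay the lower response of compound 3 is not shared by every substituted phenyl on this aromatic carbon: 2-methoxyphenyl in place of 4-methylphenyl gives a number 19 percentage points higher from compound 3 to compound 4 (beyond the scatter) and methoxy in place of hydrogen gives no change at the digits printed from compound 2 to compound 4 (within the scatter). Set against trifluoromethyl, the 2-methoxyphenyl group gives a number 2 percentage points higher from compound 1 to compound 4 (within the scatter) and this leaves compound 3 as the only member of the series with a lowered response. Nothing available accounts for the different outcomes of the two substituted phenyl groups.

On these data alone, the two groups differ both in substituent and in its place on the ring, so it stays open which of these goes with the lower response, a question that 2-methylphenyl and 4-methoxyphenyl groups would separate. As far as these compounds go, whether a hydroxyl or an amine on the same ring would behave like methoxy also stays open.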